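The source may report more compounds than this note shows. Statements on the series, on what has been measured and on what is new or still open speak of the compounds shown alone.

Measured in a functional assay on the whole organism with Mus musculus as the target; on this read-out lower numbers stand for an effect already at smaller amounts and higher numbers for an effect only at larger amounts of compound:
- compound 1 `C[C@@H](NCc1ccc(-c2ccccc2)cc1)C(N)=O`: 231 mg/kg
- compound 2 `C[C@@H](NCc1ccc(OCc2ccccn2)cc1)C(N)=O`: 172 mg/kg

Compound 2 at 172 mg/kg stands within the scatter of compound 1, so the two values do not separate these compounds. Compound 3 `C[C@@H](NCc1ccc(OCC2CC2)cc1)C(N)=O` keeps the rest of compound 2 and changes one group: cyclopropyl in place of pyridin-2-yl on a saturated chain carbon bound to an oxygen on an aromatic ring. This places cyclopropyl in place of pyridin-2-yl on a saturated chain carbon bound to an oxygen on an aromatic ring.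

Among the compounds with values here, no measured pair isolates this change, so the data give no direct size for it. In this assay, no step beyond the scatter is expected, and no direction is favoured. Within the data shown here, the only guide is that compound 1 at 231 mg/kg and compound 2 at 172 mg/kg lie within the scatter of each other. The expected change is a 1.0-fold lower number from compound 2 to compound 3 (0.02 log units; within the scatter). The estimate for compound 3 is 165 mg/kg, with an expected range of 70 mg/kg to 380 mg/kg.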

Compound 3, dose for half-maximal effect: 124 mg/kg
Estimate against measurement, compound 3: 1.3-fold (0.12 log units) above; measured number inside the range.
By their numbers in this assay, from the lowest: compounds 3, 2 and 1 (each within the scatter of the next).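

Replacing pyridin-2-yl with cyclopropyl on a saturated chain carbon bound to an oxygen on an aromatic ring gives (a 1.4-fold lower number from compound 2 to compound 3 (0.14 log units; within the scatter)) in this assay, so at this position a six-membered aromatic ring with a hetero atom and a three-membered carbon ring do not separate. The second new comparison, cyclopropylmethoxy in place of phenyl on an aromatic carbon, gives (a 1.9-fold lower number from compound 1 to compound 3 (0.27 log units; within the scatter)), so this change does not separate its two compounds either. No measured data here bear on the reason for these values.

Going by these compounds, what remains open is whether any group at this position gives a step beyond the scatter. A longer chain in place of cyclopropylmethyl, or an amine or carboxylic acid on the chain, could test this.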